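From a Pyridinyloxy Anilide to a Benzoyl Anilide

The compounds below may be only part of what the source reports. "The series", "measured", "known", "first", "only" and "open" are said of these compounds alone.

The account follows a small set of amides built on one shared core. Among the measured compounds shown here, compound 1, `O=C(Nc1cccc(Oc2ccccn2)c1)C1CCCN(C(=O)c2cc(C(F)(F)F)cc(C(F)(F)F)c2)C1`, was tested in an ADME assay on PC-3 cells (Homo sapiens) for cytotoxicity, read by WST assay, tested at 100 uM; on this read-out lower numbers stand for less inhibition and higher numbers for more inhibition at the one concentration tested (going by the name of the read-out); at the single concentration compound 1 gives 0%. Compound 3, `O=C(Nc1cccc(Cc2ccccc2)c1)C1CCCN(C(=O)c2cccc(-c3ccco3)c2)C1`, gives 0% in this assay, a number level with that of compound 1 at the digits shown and within the scatter, so these two together stand at the bottom of the three values. Compound 2, `O=C(Nc1ccc(Cl)cc1)C1CCCN(C(=O)c2cccc(-c3nccs3)c2)C1`, gives 32% in this assay, a number that lies above that of compound 1 by more than the scatter.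

The step considered here leads from compound 1 to compound 4, `O=C(c1ccccc1)c1cccc(NC(=O)C2CCCN(C(=O)c3cc(C(F)(F)F)cc(C(F)(F)F)c3)C2)c1`. The change is benzoyl in place of (pyridin-2-yl)oxy on an aromatic carbon. For the measured compounds named here, no pair of measured compounds differs in this one place alone, so the size of such a step is not known from the data; two different groups on that aromatic carbon, in compound 1 and compound 3, both sit at the floor of the read-out. The step of a number 6 percentage points higher from compound 1 to compound 4 (within the scatter) is therefore expected to be small, at most a modest rise, none that clearly exceeds the scatter. Compound 4 is expected to give 6% in this assay, within a range from 0% to 25%.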

Compound 4, a percentage reported as inhibition, at one concentration (the size of the read-out at that concentration, not a potency): 0%
Compound 4: the middle estimate sits 6 percentage points above what was measured; the range from low to high includes it.
By their numbers in this assay, from the lowest: compounds 1, 3 and 4 (each within the scatter of the next); then compound 2.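

Exchanging (pyridin-2-yl)oxy for benzoyl on this aromatic carbon, meta to a large group, brings no change at the digits printed from compound 1 to compound 4 (within the scatter) in this assay. Among the compounds shown here, this pair is the first to isolate that one place, and it shows that replacing the pyridine ring and its ether oxygen with a ring of carbon only, joined through a carbonyl, does not lift the number above the floor of the read-out on this bis(trifluoromethyl)benzoyl background. The pair cannot show any fall, with both compounds at the floor, and no measurement shown accounts for the lack of change.

From the compounds shown here alone, it remains open whether an amine or a carboxylic acid on this same aromatic carbon, or a longer chain such as a benzyloxy group, would move the number in this assay on this background. Compound 2 differs from the other compounds in more than one place, so its higher number cannot be traced to any single group, and whether a chlorine on the anilide ring or a thiazole on the benzoyl ring would raise the number here also stays unanswered.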